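This account rests on a few compounds, and the source may have more. Where it says the series, first, only, none or still open, it means among the compounds named here.

Measured compounds in a functional assay for inhibition, with a stated time of 30 min; on this read-out higher numbers stand for weaker inhibition and lower numbers for stronger inhibition:
- compound 1, `c1ccc(-c2[nH]c3ccccc3c2C2CC(c3ccncc3)=NO2)cc1`: 59.9 ug/mL
- compound 2, `O=C(c1ccccc1)N1N=C(c2cccnc2)CC1c1c(-c2ccccc2)[nH]c2ccccc12`: 48.2 ug/mL
- compound 3, `O=C(c1ccccc1)N1N=C(c2ccncc2)CC1c1c(-c2ccccc2)[nH]c2ccccc12`: 107 ug/mL

Compound 2 and compound 3 share a core and differ in one place. The change is pyridin-3-yl in place of pyridin-4-yl on a carbon with a double bond to nitrogen and it gave a 2.2-fold lower number from compound 3 to compound 2 (0.35 log units; beyond the scatter), a step that lies beyond the usual scatter of this assay.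

Compound 1 carries a different core. How the core of compound 1 and the core of compound 3 differ is not broken down here. The numbers for compound 1 and compound 2 sit within the scatter of each other, as do those for compound 1 and compound 3, so no order among these three is read from the data.

Compound 4, `c1ccc(-c2[nH]c3ccccc3c2C2CC(c3cccnc3)=NO2)cc1`, is not yet measured. It stands to compound 1 as compound 2 stands to compound 3: the change is pyridin-3-yl in place of pyridin-4-yl on a carbon with a double bond to nitrogen. The surroundings are not the same word for word. In compound 1 the carbon with a double bond to nitrogen belongs to a five-membered non-aromatic ring with 1 nitrogen and 1 oxygen, two ring bonds from the ring oxygen; in compound 3 the ring has 2 nitrogen, and the ring atom two ring bonds away bears a benzoyl group. The change is therefore the same kind of change, not the same change.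

For compound 4 the step is expected to resemble the earlier one, because compound 3 to compound 2 gave a 2.2-fold lower number from compound 3 to compound 2 (0.35 log units; beyond the scatter) for this kind of change; the expected step from compound 1 to compound 4 is a 1.9-fold lower number from compound 1 to compound 4 (0.27 log units; within the scatter). That expectation rests on a single pair and on a different core, so the range is kept wide. Compound 4 is estimated at 32 ug/mL, between 15 ug/mL and 65 ug/mL.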

Compound 4, half-maximal inhibitory concentration: 60.7 ug/mL
Beside the measured number, compound 4's estimate is 1.9-fold (0.28 log units) below it, within the range that was stated.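

In this assay, for the compounds shown here, pyridin-3-yl in place of pyridin-4-yl on a carbon with a double bond to nitrogen gave a 1.0-fold higher number from compound 1 to compound 4 (0.01 log units; within the scatter), so on the core of compound 1 this change produces no step that can be told from the scatter. Set beside the step on the other core, this result does not differ from it by more than the scatter allows: the same change on two cores in this assay, a 2.2-fold lower number (0.35 log units; beyond the scatter) from compound 3 to compound 2 and a 1.0-fold higher number (0.01 log units; within the scatter) from compound 1 to compound 4, 2.2-fold (0.35 log units) apart, within the scatter of two such steps. Going by these compounds alone, the data therefore do not show that the change behaves differently on the two cores, nor do they show that it carries over, since one step lies beyond the scatter, the other within it, and each core offers only a single pair.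

The compounds shown leave open how pyridin-2-yl, or a phenyl bearing an amine or a carboxylic acid, would read at this same carbon on either core, and whether any such group would give a step large enough to be compared across cores with confidence. They also leave open whether the benzoyl group of compound 2 and compound 3 plays any part in the step seen on that core, which a pair carrying acetyl in its place could address.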